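The source may hold more compounds than are shown below. What is called first, only, known or untested is meant among the compounds shown, and "the series" means these compounds.

Measured so far in an ADME assay on HepG2 cells (Homo sapiens) for cytotoxicity, read by resazurin assay, with a stated time of 48 h; on this read-out lower numbers stand for an effect already at smaller amounts and higher numbers for an effect only at larger amounts of compound:
Compound 1 `O=C(Nc1ccc(F)c(-c2nc3ncc(-c4ccc(F)c(F)c4)cc3[nH]2)c1)N1CCCC1`: > 50000 nM, a limit of the assay.
Compound 2 `O=C(Nc1ccc(F)c(-c2nc3ncc(-c4cc(F)ccc4F)cc3[nH]2)c1)N1CCCC1`: > 50000 nM, a limit of the assay.

Compound 2 is known only as a limit, not as a number. Among the measured compounds shown here, the same holds for the only other measured compound, and the series so far stands at the limit of > 50000 nM in this assay, at which 2 of the 2 values shown sit.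

The next change leads to compound 3 `O=C(Nc1ccc(F)c(-c2nc3ncc(-c4ccc(F)cc4F)cc3[nH]2)c1)N1CCCC1`: 2,4-difluorophenyl in place of 2,5-difluorophenyl on an aromatic carbon, with 2,4-difluorophenyl in place of 2,5-difluorophenyl on an aromatic carbon. The atoms are the same, joined differently.

For the measured compounds named here, the one measured step that bears on this is a step that the two limits leave unreadable from compound 1 to compound 2, which also exchanges one difluorophenyl for another at the same place. It offers no size to carry over, so the expectation rests on both measured compounds sitting at the limit. No step beyond the usual scatter is expected, and no direction is favoured. The expected change in this assay is a number no higher from compound 2 to compound 3 (the limit leaves the size open). A report of compound 3 as a limit again is the likeliest outcome. The estimate for compound 3 is 50000 nM, with an expected range from 20000 nM to 100000 nM.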

Compound 3, half-maximal effective concentration: 32400 nM
For compound 3 the middle estimate is 1.5-fold (0.19 log units) above the measured one; low and high end bracket the measured number.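

In this assay, among the compounds shown here, compound 3 gives 32400 nM, the only value shown that is a number and not a limit, so with 2,4-difluorophenyl at this aromatic carbon the read-out can be placed for the first time. Against the other two arrangements of the two fluorines, the result reads as an at least 1.5-fold lower number from compound 2 to compound 3 (0.18 log units; that floor lies within the scatter) and as an at least 1.5-fold lower number from compound 1 to compound 3 (0.18 log units; that floor lies within the scatter); both are floors, so the swap of fluorine positions on this ring is not yet shown to act beyond the scatter, though it is not shown to stay within it either. The step between the two other compounds cannot be read, and every comparison at this position has a limit at one end: the limit of > 50000 nM in this assay, at which 2 of the 3 values shown sit.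

Still open, going by these compounds, is how far the read-out of compound 1 and compound 2 lies from that of compound 3, as only limits stand for those two. Also open, on these data alone, is how this position, para to a fused ring, responds to groups other than a difluorophenyl, such as an unsubstituted phenyl, a carboxylic acid or a chain ending in an amine.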